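A few compounds are considered here, and "the series" means these few. Any claim that something is new, unique, unknown or untested is made for them only; others in the source may bear on it.

Values so far in a functional assay on LoVo cells (Homo sapiens) for cytotoxicity, read by MTT assay, with a stated time of 72 h; a lower number here means a stronger inhibitor, a higher number a weaker inhibitor
- compound 1 `COc1ccc2[nH]c(-c3ccc[nH]3)c(C3CC(=O)NC3=O)c2c1` gives 4000 nM
- compound 2 `COc1ccc2[nH]c(-c3ccc[nH]3)cc2c1` gives 26000 nM
- compound 3 `COc1ccc2[nH]c3c4cn[nH]c4c4c(c3c2c1)C(=O)NC4=O` gives 42000 nM

Not yet measured: compound 4 `Cc1ccc2[nH]c(-c3ccc[nH]3)c(C3CC(=O)NC3=O)c2c1`.

Compound 1 has the lowest number of the three, and its gaps to compound 2 and compound 3 both lie beyond the scatter. Compound 4 differs from it by methyl in place of methoxy on an aromatic carbon, on a six-membered aromatic ring of carbon only, part of a fused or bridged system of two rings.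

Within the data shown here, only one measured step is available, a 6.5-fold higher number from compound 1 to compound 2 (0.81 log units; beyond the scatter), and it bears on this change only indirectly. That step replaces 2,5-dioxopyrrolidin-3-yl with hydrogen at a different place, while methoxy stays in both compounds. Compound 4 keeps the 2,5-dioxopyrrolidin-3-yl group, so its number should stay nearer to that of compound 1 than to that of compound 2. Among the measured compounds shown here, no measured pair changes the methoxy, so the data give neither a size nor a direction for this replacement. No step beyond the scatter is therefore expected in this assay, although the uncertainty is wide.

The expected size is a 1.3-fold higher number from compound 1 to compound 4 (0.10 log units; within the scatter), which stays within the scatter. Compound 4 is estimated at 5000 nM (expected range 1500 nM to 16000 nM).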

Compound 4, half-maximal inhibitory concentration: 4000 nM
Compound 4: middle estimate off by 1.3-fold (0.10 log units), on the high side, and the stated range covers the measured number.
By their numbers in this assay, from the lowest: compounds 1 and 4 (each within the scatter of the next); then compounds 2 and 3 (each within the scatter of the next).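

In this assay, among these compounds, methyl in place of methoxy on this aromatic carbon, which is meta to one fused ring and para to another, gives no change at the digits printed from compound 1 to compound 4 (within the scatter), the first measured change at a place where compounds 1, 2 and 3 all carry methoxy. With the 2,5-dioxopyrrolidin-3-yl group present, the oxygen of the methoxy and the hydrogen-bond acceptor counted on it can therefore be given up without a step beyond the scatter, so this one pair shows that methoxy is not required at this carbon for the number seen with compound 1. No supporting measurement bears on why the two compounds read alike.

The compounds shown leave open how a hydroxyl, an amine, a carboxylic acid, a chlorine atom or a longer chain such as butoxy would read at this same carbon, and so whether the result extends past this single replacement. They also leave open whether methyl and methoxy remain within the scatter of each other when hydrogen stands in place of the 2,5-dioxopyrrolidin-3-yl group, as methyl appears here only alongside that group.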